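The source may report more compounds than this note shows. Statements on the series, on what has been measured and on what is new or still open speak of the compounds shown alone.

Two compounds set the scene. Among the measured compounds shown here, in a functional assay on HEK293 cells for antagonist activity at transient receptor potential cation channel subfamily V member 1 (Rattus norvegicus) (on this read-out higher numbers stand for weaker inhibition and lower numbers for stronger inhibition), compound 1 `O=C(Nc1ccc(Oc2ccccc2)cc1)N1CCN(c2ncccc2C(F)(F)F)CC1` gives 258 nM, whereas compound 2 `CC(C)c1ccc(NC(=O)N2CCN(c3ncccc3Br)CC2)cc1` gives 4.6 nM, the lower of the two numbers, with compound 1 as its only neighbour standing well beyond the scatter above it. Compound 3 `CC(C)c1ccc(NC(=O)N2CCN(c3ncccc3C=O)CC2)cc1` differs from compound 2 in one place: formyl in place of bromo on an aromatic carbon. For the measured compounds named here, no measured pair shows this change, so the expected step of an 8.7-fold higher number from compound 2 to compound 3 (0.94 log units; beyond the scatter) is a moderate move toward weaker inhibition, not certain to clear the scatter. Compound 3 is therefore estimated at 40 nM, within 8 nM to 250 nM.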

Compound 3, half-maximal inhibitory concentration: 201 nM
Beside the measured number, compound 3's estimate is 5.0-fold (0.70 log units) below it, and the stated range covers the measured number.
By their numbers in this assay, from the lowest: compound 2; then compounds 3 and 1 (each within the scatter of the next).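

In this assay the change from 3-bromopyridin-2-yl to 3-formylpyridin-2-yl gives a 44-fold higher number from compound 2 to compound 3 (1.64 log units; beyond the scatter) and so shows that inhibition depends strongly on the group at this place, on an aromatic carbon two atoms from the ring nitrogen. This single change, with the rest of the molecule held fixed, is enough to lose most of the inhibition seen with bromo. Nothing measured here explains the size of this step. As far as these compounds go, whether chloro, nitrile or hydroxymethyl at this place would stay close to bromo or fall toward formyl remains open.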